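The compounds below may be only part of what the source reports. "The series", "measured", "known", "first", "only" and "open" are said of these compounds alone.

Working notes on a series built on one shared core. In an ADME assay on A549 cells (Homo sapiens) for cytotoxicity, read by CellTiter-Glo (on this read-out lower numbers stand for higher toxicity in this test and higher numbers for lower toxicity in this test), compound 1 `Cc1c(Cc2ccc(F)cc2)c(=O)oc2cc(OCC(O)CN3CCC(C(N)=O)CC3)ccc12` gives 89300 nM. Compound 2 `Cc1c(Cc2ccc(C(F)(F)F)cc2)c(=O)oc2cc(OCC(O)CN3CCC(C(N)=O)CC3)ccc12` gives 89300 nM in this assay. Compound 3 `Cc1c(Cc2ccc(-c3ccccc3)cc2)c(=O)oc2cc(OCC(O)CN3CCC(C(N)=O)CC3)ccc12` reaches only a limit in this assay, > 100000 nM, which is a limit of the assay and not a number. Compound 3 therefore stands at the upper edge of the three values shown, its value sitting at the limit of > 100000 nM in this assay, at which 1 of the 3 values shown sits.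

The measured steps all exchange the group on the same aromatic carbon of the pendant ring. From compound 1 to compound 2 the read-out shows no change at the digits printed from compound 1 to compound 2 (within the scatter). From compound 1 to compound 3 it shows an at least 1.1-fold higher number from compound 1 to compound 3 (0.04 log units; that floor lies within the scatter), and from compound 2 to compound 3 an at least 1.1-fold higher number from compound 2 to compound 3 (0.04 log units; that floor lies within the scatter). None of these moves beyond the scatter.

Compound 4 `Cc1c(Cc2ccc(-c3ccc(C#N)c(F)c3)cc2)c(=O)oc2cc(OCC(O)CN3CCC(C(N)=O)CC3)ccc12` is not yet measured. Its structural change is 4-cyano-3-fluorophenyl in place of phenyl on an aromatic carbon, a further exchange on the same aromatic carbon. The three measured steps on this carbon were all flat, so for compound 4 no step beyond the scatter is expected in this assay, and the expected step is a number no higher from compound 3 to compound 4 (the limit leaves the size open). The estimate for compound 4 in this assay is 100000 nM, with a range from 50000 nM to 200000 nM.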

Compound 4, half-maximal cytotoxic concentration: 29100 nM
Compound 4: the middle estimate sits 3.4-fold (0.54 log units) above what was measured, outside the stated range (below it).
By their numbers in this assay, from the lowest: compound 4; then compounds 1 and 2 (each within the scatter of the next). At a limit, above all of these: compound 3.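

In this assay, none of the exchanges among fluoro, trifluoromethyl and phenyl on this aromatic carbon moved the read-out beyond the scatter, but 4-cyano-3-fluorophenyl does, with an at least 3.4-fold lower number from compound 3 to compound 4 (0.53 log units; beyond the scatter), a 3.1-fold lower number from compound 2 to compound 4 (0.49 log units; beyond the scatter) and a 3.1-fold lower number from compound 1 to compound 4 (0.49 log units; beyond the scatter). Going by these compounds alone, the position is therefore not indifferent to what it carries, and in this set of four the only change beyond the scatter, in the direction of higher toxicity in this test, appears when a nitrile and a fluoro are added to the phenyl group of compound 3. Compound 3 stands at a limit and not at a number, so the step from it gives only a floor, and its true size stays unknown: the limit of > 100000 nM in this assay, at which 1 of the 4 values shown sits.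

Which of the two added groups carries the step stays open, since both enter together in compound 4. Also open is how a phenyl with the nitrile alone, the fluoro alone, or a carboxylic acid or an amine in their place would read in this assay, and the compounds shown give no cause for the step.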